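The source may report more compounds than this note shows. Statements on the series, on what has been measured and on what is new or still open speak of the compounds shown alone.

Compound 1 `CCn1cc(-c2nc3ccc(Cl)cc3[nH]2)c(=O)c2cc(F)c(N3CCNCC3)cc21` carries a chloro group on an aromatic carbon and a piperazine ring on the shared core. In a functional assay on HepG2 cells (Homo sapiens) for cytotoxicity, read by sulforhodamine B assay, with a stated time of 48 h (a lower number here means a stronger inhibitor, a higher number a weaker inhibitor), compound 1 gives 3700 nM. Compound 2 `CCn1cc(-c2nc3ccc(N)cc3[nH]2)c(=O)c2cc(F)c(N3CCNCC3)cc21` replaces that chloro group with an amino group. In this assay compound 2 gives > 10000 nM, which is a limit of the measurement rather than a number. The step of an at least 2.7-fold higher number from compound 1 to compound 2 (0.43 log units; beyond the scatter) therefore shows only a weakening of at least that size, because compound 2 sits at the limit of > 10000 nM in this assay, at which 1 of the 2 values shown sits. Compound 3 `CCn1cc(-c2nc3ccc(N)cc3[nH]2)c(=O)c2cc(F)c(N3CCN(C)CC3)cc21` differs from compound 2 by methyl in place of hydrogen on an amine nitrogen in a ring. Within the data shown here, no measured step touches an amine nitrogen in a ring, so nothing among the two measured compounds speaks directly to this change; the only measured step concerns the aromatic carbon. Compound 2 already sits at the limit. For compound 3 the expected step is a step that the limit leaves unreadable from compound 2 to compound 3, nothing beyond the scatter. Compound 3 is therefore expected to give about 15000 nM in this assay, with a range from 6000 nM to 50000 nM, and a good chance that only a limit is reported again.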

Compound 3, half-maximal inhibitory concentration: > 10000 nM
Compound 3: a limit, no number (the forecaster's own chance of this, stated with the estimate: 70%); the middle value lies beyond the limit too.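

In this assay, compound 2 and compound 3 each give only a limit rather than a number, so no step between them can be read, because both sit at that same limit: the limit of > 10000 nM in this assay, at which 2 of the 3 values shown sit.

The compounds shown leave open whether methyl in place of hydrogen on an amine nitrogen in a ring changes the result in this assay at all.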